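The compounds below may be only part of what the source reports. "The series", "measured", "known", "first", "only" and "open" are said of these compounds alone.

Measured in a functional assay on FaDu cells (Homo sapiens) for inhibition, read by sulforhodamine B assay; a higher number here means a weaker inhibitor, a lower number a stronger inhibitor:
Compound 1 `COC(=O)CC/C(C)=C/Cc1c(OC)c(C)c2c(c1OCC#CCN1CCN(c3ccccc3F)CC1)C(=O)OC2`: > 50000 nM
Compound 2 `COC(=O)CC/C(C)=C/Cc1c(OC)c(C)c2c(c1OCC#CCN1CCN(c3ccc(O)cc3)CC1)C(=O)OC2`: > 50000 nM
Compound 3 `COC(=O)CC/C(C)=C/Cc1c(OC)c(C)c2c(c1OCC#CCN1CCN(c3ccccc3OC)CC1)C(=O)OC2`: > 50000 nM

Compound 3 stands at > 50000 nM, which is a limit of the assay and not a number. The other two measured compounds stand at the same limit, so the whole set reads as the limit of > 50000 nM in this assay, at which 3 of the 3 values shown sit.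

Compound 4 `COC(=O)CC/C(C)=C/Cc1c(OC)c(C)c2c(c1OCC#CCN1CCN(C(=O)C3COc4ccccc4O3)CC1)C(=O)OC2` carries (2,3-dihydro-1,4-benzodioxin-2-yl)carbonyl in place of 2-methoxyphenyl on an amine nitrogen in a ring.

The measured steps that bear on this change all exchange the phenyl group on that same nitrogen or its substituent: a step that the two limits leave unreadable from compound 1 to compound 3, a step that the two limits leave unreadable from compound 2 to compound 3 and a step that the two limits leave unreadable from compound 1 to compound 2. None of them has a readable size. As far as these compounds go, none of the three measured compounds carries a carbonyl on that nitrogen, so the new group is untested in this set.

In this assay no step beyond the scatter is therefore expected, and compound 4 is expected to stay at the limit. If a number does appear, the expected direction is towards a stronger inhibitor, though only modestly. The expected step is a number no higher from compound 3 to compound 4 (the limit leaves the size open). For compound 4 the estimated value is 50000 nM, with an expected range from 20000 nM to 100000 nM.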

Compound 4, half-maximal inhibitory concentration: > 50000 nM
Compound 4: no number, only a limit; the forecaster's own chance of this, stated with the estimate: 75%; the middle value lies on the limit itself.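

In this assay compound 4 gives > 50000 nM, which is a limit of the assay and not a number. No step to compound 4 from compound 1, compound 2 or compound 3 can be read, and the whole set now rests at one reading: the limit of > 50000 nM in this assay, at which 4 of the 4 values shown sit.

The compounds shown leave open whether any group on that amine nitrogen can give a measurable value in this assay.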